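Aminothiophene ketones as adenosine receptor positive allosteric modulators

The compounds below may be only part of what the source reports. "The series", "measured", "known", "first", "only" and "open" are said of these compounds alone.

Measured compounds:
compound 1 `Nc1sccc1C(=O)c1ccc(Cl)cc1` 40%
compound 2 `Nc1sc(-c2ccccc2)cc1C(=O)c1ccccc1` 1%
compound 3 `COc1ccc(-c2cc(C(=O)c3ccccc3)c(N)s2)cc1` 14%

In an assay on CHO cells for positive allosteric modulation of adenosine receptor A1 (Homo sapiens), read by ERK phosphorylation, tested at 10 uM (a higher number here means a weaker effect of the compound at the concentration tested, a lower number a stronger effect), compound 3 stands second highest of the three numbers; compound 2 is nearest, lower beyond the scatter, and compound 1 is furthest, higher beyond the scatter. Compound 4 `CN(C)c1ccc(-c2cc(C(=O)c3ccccc3)c(N)s2)cc1` is not yet measured. It differs from compound 3 by dimethylamino in place of methoxy on an aromatic carbon. For the measured compounds named here, the only measured step at this position is a number 13 percentage points higher from compound 2 to compound 3 (beyond the scatter), a modest rise on going from hydrogen to methoxy. Going by the values given here, no measured pair shows methoxy against dimethylamino, so the direction of a further change is open. On this basis a small step, a number 4 percentage points higher from compound 3 to compound 4 (within the scatter), is expected in this assay, not far beyond the scatter. Compound 4 is therefore estimated at 18%, within 5% to 40%.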

Compound 4, a percentage reported as activity, at one concentration (the size of the read-out at that concentration, not a potency): 29%
The estimate for compound 4 lay 11 percentage points below the measured number, and the stated range covers the measured number.
By their numbers in this assay, from the lowest: compound 2; then compound 3; then compound 4; then compound 1.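

In this assay the substituent para to a large group on the six-membered aromatic ring still matters once methoxy is present, with a number 15 percentage points higher from compound 3 to compound 4 (beyond the scatter) for dimethylamino in place of methoxy. Hydrogen, methoxy and dimethylamino now form a rising order of numbers, meaning a weakening effect, and a number 28 percentage points higher from compound 2 to compound 4 (beyond the scatter) spans that order. Nothing available accounts for this order. From the compounds shown here alone, whether a carboxylic acid or a primary amine at this position would continue the order remains open.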